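The source may hold more compounds than are shown below. What is called first, only, known or untested is meant among the compounds shown, and "the series" means these compounds.

Compound 1 `Cn1cncc1CN1CC(N(CC2CCN(C(=O)C3CC3)CC2)S(=O)(=O)c2ccccn2)Cc2cc(C#N)ccc21` has been tested in an ADME assay on Caco-2 cells (Homo sapiens) for permeability, in the apical to basolateral direction; on this read-out lower numbers stand for lower permeability and higher numbers for higher permeability; compound 1 gives 0.5 10^-6 cm/s. Two companions share its core and differ only at the carbonyl on the piperidine ring. Compound 2 `Cn1cncc1CN1CC(N(CC2CCN(C(=O)NC(C)(C)C)CC2)S(=O)(=O)c2ccccn2)Cc2cc(C#N)ccc21` gives 0.6 10^-6 cm/s, and compound 3 `Cn1cncc1CN1CC(N(CC2CCN(C(=O)c3cccs3)CC2)S(=O)(=O)c2ccccn2)Cc2cc(C#N)ccc21` gives 0.5 10^-6 cm/s. Among these three numbers, compound 1 sits level with compound 3 at the digits shown, the two lowest, and its furthest companion is compound 2: the step of a 1.2-fold higher number from compound 1 to compound 2 (0.08 log units; within the scatter), the step of no change at the digits printed from compound 1 to compound 3 (within the scatter), and the step of a 1.2-fold lower number from compound 2 to compound 3 (0.08 log units; within the scatter) all stay inside the usual scatter of this read-out.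

Compound 4 `Cc1noc(C)c1CN(C1Cc2cc(C#N)ccc2N(Cc2cncn2C)C1)S(=O)(=O)c1ccccn1` is not yet measured. It differs from compound 1 as follows: 3,5-dimethyl-1,2-oxazol-4-yl in place of 1-(cyclopropylcarbonyl)piperidin-4-yl on a saturated chain carbon bound to a sulfonamide nitrogen. The three measured steps each swap only the group on the carbonyl carbon and leave the piperidine in place; none of them removes that ring, so they do not speak directly to this change. They do show that this part of the molecule tolerated three variations without moving this assay. The expectation for compound 4 therefore rests on the value of compound 1 with a wide margin: compound 4 is estimated at 1 10^-6 cm/s, in a range from 0.3 10^-6 cm/s to 4 10^-6 cm/s, which means an expected step of a 2.0-fold higher number from compound 1 to compound 4 (0.30 log units; within the scatter).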

Compound 4, apparent permeability: 8 10^-6 cm/s
Compound 4: the middle estimate sits 8.0-fold (0.90 log units) below what was measured, and the stated range ends below it.
By their numbers in this assay, from the lowest: compounds 1, 3 and 2 (each within the scatter of the next); then compound 4.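

In this assay, going by these compounds alone, the earlier steps changed only the group on the carbonyl carbon, left the piperidine in place and stayed within the scatter, whereas replacing the whole 1-(cyclopropylcarbonyl)piperidin-4-yl with 3,5-dimethyl-1,2-oxazol-4-yl on the saturated chain carbon bound to the sulfonamide nitrogen gives a 16-fold higher number from compound 1 to compound 4 (1.20 log units; beyond the scatter). This position therefore responds to an exchange of the whole group, even though three different groups on the carbonyl carbon left the number within the scatter. The exchange changes several things at once, going from 11 heavy atoms to 7 and from two non-aromatic rings to one five-membered aromatic ring, and no measurement here explains why the number moves.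

The compounds shown do not separate the loss of the acylated piperidine from the arrival of the aromatic ring, so it remains open which of the two matters. A plain phenyl ring at this place would address the role of an aromatic ring without the ring's hetero atoms, while a piperidin-4-yl with a free amine, or a short alkyl chain such as isobutyl, would show what happens with other non-aromatic groups.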